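Working notes: shortening the substituent on the ring nitrogen

This account rests on a few compounds, and the source may have more. Where it says the series, first, only, none or still open, it means among the compounds named here.

Measured compounds:
Compound 1, `CCCC(=O)n1nc(C)c(-c2ccc(Cl)c(Cl)c2)c1N`: > 100000 nM
Compound 2, `Cc1nn(C(=O)c2cccnc2)c(N)c1-c1ccc(Cl)c(Cl)c1`: > 100000 nM

In an assay on Sf9 cells for inhibition of inhibitor of nuclear factor kappa-B kinase subunit epsilon (Homo sapiens), read by ADP-Glo, with a stated time of 60 min (a higher number here means a weaker inhibitor, a lower number a stronger inhibitor), compound 1 gives > 100000 nM, and this value is a limit of the assay, not a number. In this assay compound 2 likewise gives > 100000 nM, again a limit. Within the data shown here, the only measured step, a step that the two limits leave unreadable from compound 1 to compound 2, is therefore not readable in size or direction; both values sit at the same boundary, as the limit of > 100000 nM in this assay, at which 2 of the 2 values shown sit, records. Nothing measured shows whether the group on the carbonyl carbon matters.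

The next compound, compound 3, is `Cc1nn(C)c(N)c1-c1ccc(Cl)c(Cl)c1`. It differs from compound 1 by methyl in place of propylcarbonyl on an aromatic nitrogen. Among the measured compounds shown here, no measured step touches this position in a readable way: the one step from compound 1 to compound 2 changes a different part and gives no size. For the measured compounds named here, with both measured values at the limit, no size of step in this assay can be expected from the data; the series so far offers no case where a number was reached.

Compound 3 is therefore expected to give about 100000 nM in this assay, within 20000 nM to 300000 nM, a step of a number no higher from compound 1 to compound 3 (the limit leaves the size open), with a substantial chance that only a limit is reported again.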

Compound 3, half-maximal inhibitory concentration: > 100000 nM
Compound 3 gave a limit, no number (the forecaster's own chance of this, stated with the estimate: 70%); the middle value sits exactly at the limit.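

In this assay compound 3 gives > 100000 nM, which is a limit and not a number. No step can be read between compound 1 and compound 3, and the series stays at one boundary: the limit of > 100000 nM in this assay, at which 3 of the 3 values shown sit.

The compounds shown leave open whether any group on the aromatic nitrogen of the shared core affects inhibition in this assay.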